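A few compounds are considered here, and "the series" means these few. Any claim that something is new, unique, unknown or untested is made for them only; others in the source may bear on it.

Measured compounds:
compound 1, `COc1ccc2nc(C(=O)Nc3ccc(-c4ccccc4)cc3)c(C)c(O)c2c1`, 36.3%
compound 2, `Cc1c(C(=O)Nc2ccc(-c3ccccc3)cc2)nc2ccccc2c1O`, 38.3%
compound 3, `CCc1ccc2nc(C(=O)Nc3c(F)cc(-c4cccc(F)c4)cc3F)c(C)c(C(=O)O)c2c1`, 27.2%

In a functional assay on Hep 3B2 cells (Homo sapiens) for antiproliferative activity, read by MTT assay, with a stated time of 24 h, tested at 11.11 ug/mL (a lower number here means a weaker effect, a higher number a stronger effect of the compound at the concentration tested), compound 2 gives 38.3%, the highest of the three numbers. Compound 1 sits nearest to it, and the step of a number 2 percentage points higher from compound 1 to compound 2 (within the scatter) comes from hydrogen in place of methoxy on an aromatic carbon, a change within the scatter. Among the compounds with values here, compound 3 lies furthest away, and its value in this assay is 27.2%, a gap beyond the scatter; no single step links it to compound 2, since compound 3 differs from it in several places at once.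

Compound 4, `Cc1c(C(=O)Nc2ccc(-c3ccccc3)cc2)nc2ccccc2c1C(=O)O`, has not been measured. It differs from compound 2 by carboxy in place of hydroxy on an aromatic carbon. Within the data shown here, no measured step bears directly on this change: the only single-place step, from compound 1 to compound 2, concerns a different position and was within the scatter. Compound 3, which carries a carboxy group in the same place among other changes, gives a lower number than compound 2, but that comparison is not clean. The step from compound 2 to compound 4 is therefore expected to be modest, with a downward lean, and is estimated as a number 7.3 percentage points lower from compound 2 to compound 4 (within the scatter). Compound 4 is expected to give 31% in this assay, between 17% and 45%.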

Compound 4, a percentage reported as inhibition, at one concentration (the size of the read-out at that concentration, not a potency): 3.25%
Compound 4: middle estimate off by 27.8 percentage points, on the high side, outside the stated range (below it).
By their numbers in this assay, from the lowest: compound 4; then compounds 3, 1 and 2 (each within the scatter of the next, the first and the last beyond it).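

In this assay, within the data shown here, carboxy in place of hydroxy on an aromatic carbon opposite the ring nitrogen gives a number 35.1 percentage points lower from compound 2 to compound 4 (beyond the scatter), the only large single-place step seen so far. The earlier single-place step, a number 2 percentage points higher from compound 1 to compound 2 (within the scatter), involved methoxy and hydrogen and stayed within the scatter, so it gave no sign that one change on the shared core could move the read-out this far. The new step shows that this position, ortho to a methyl group and to a fused ring, is sensitive to the group it carries, at least for this pair of compounds, though nothing measured here explains the drop.

The compounds shown leave open how an amine, a methyl ester or a carboxamide at this same place would compare with hydroxy and carboxy, and so whether the large step is tied to carboxy alone. Among these compounds, they also leave open whether a step of this size would recur with other groups on the rest of the shared core, since this single pair is the only clean comparison at this position.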